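The compounds below may be only part of what the source reports. "The series", "measured", "known", "first", "only" and "open" are said of these compounds alone.

Measured so far:
compound 1, `COc1ccc2nc(C)cc(OCCNc3cc(C)cc(C)c3)c2c1`: 33000 nM
compound 2, `COc1ccc2nc(C)cc(OCC(=O)Nc3cc(C)ccc3C)c2c1`: 45500 nM

In a physicochemical assay for solubility, in phosphate buffer, measured as kinetic solubility, with a stated time of 1 h, at pH 7.4 (a lower number here means a less soluble compound, a higher number a more soluble compound), compound 2 gives 45500 nM and compound 1 gives 33000 nM; the two numbers lie within the scatter of each other, so compound 2 is not separated from compound 1 on this assay. Compound 3, `COc1ccc2nc(C)cc(OCC(=O)Nc3cc(C)c(F)c(C)c3)c2c1`, carries 4-fluoro-3,5-dimethylphenyl in place of 2,5-dimethylphenyl on an amide-type nitrogen. Among the compounds with values here, no measured pair shows this change. Both groups keep the same donor and acceptor count and only one fluorine enters; the step from compound 2 to compound 3 is expected to be small and is estimated as a 1.4-fold lower number from compound 2 to compound 3 (0.15 log units; within the scatter), with a slight lean toward a lower number. Compound 3 is therefore expected near 32000 nM, within 14000 nM to 75000 nM.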

Compound 3, solubility: 31500 nM
Beside the measured number, compound 3's estimate is 1.0-fold (0.01 log units) above it, and the stated range covers the measured number.
By their numbers in this assay, from the lowest: compounds 3, 1 and 2 (each within the scatter of the next).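

In this assay the step of a 1.4-fold lower number from compound 2 to compound 3 (0.16 log units; within the scatter) is the only one read at this place, on an amide-type nitrogen whose other neighbour is the carbonyl carbon. 4-Fluoro-3,5-dimethylphenyl in place of 2,5-dimethylphenyl thus leaves compound 2 and compound 3 unseparated on this read-out. No measurement at hand bears on the reason for this result.

The fluorine and the changed methyl placement enter together, so neither can be read alone. From the compounds shown here alone, whether an amine or a carboxylic acid on this phenyl would move the number beyond the scatter stays open.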